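A Methyl Group on the Phenyl of Compound 3

The source may hold more compounds than are shown below. What is called first, only, known or untested is meant among the compounds shown, and "the series" means these compounds.

In a functional assay on LN-229 cells (Homo sapiens) for antiproliferative activity, with a stated time of 72 h (on this read-out lower numbers stand for stronger inhibition and higher numbers for weaker inhibition), compound 1 `CCCCC#Cc1cc([C@@H]2O[C@H](CO)[C@@H](O)[C@H]2O)n2ncnc(N)c12` gives 1000 nM as its measured value. Compound 2 `Nc1ncnn2c([C@@H]3O[C@H](CO)[C@@H](O)[C@H]3O)cc(C#Cc3ccc(F)cc3)c12` stands at > 100000 nM and that is a limit of the assay. Compound 3 `Nc1ncnn2c([C@@H]3O[C@H](CO)[C@@H](O)[C@H]3O)cc(-c3ccccc3)c12` gives 75100 nM as the higher of the two true numbers. Compound 4 `Cc1ccccc1-c1cc([C@@H]2O[C@H](CO)[C@@H](O)[C@H]2O)n2ncnc(N)c12` differs from compound 3 by methyl in place of hydrogen on an aromatic carbon as methyl in place of hydrogen on an aromatic carbon, ortho to a large group. The measured steps closest to this change, a 75-fold higher number from compound 1 to compound 3 (1.88 log units; beyond the scatter) and an at least 1.3-fold lower number from compound 2 to compound 3 (0.12 log units; that floor lies within the scatter), each exchange a whole group and do not test a methyl on the phenyl, so they offer only weak guidance. The expected change, a 1.3-fold lower number from compound 3 to compound 4 (0.10 log units; within the scatter), stays within the scatter in this assay with no firm direction. Compound 4 is estimated at 60000 nM with 20000 nM to 100000 nM as its expected range.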

Compound 4, half-maximal inhibitory concentration: > 100000 nM
Compound 4: a limit, no number (the forecaster's own chance of this, stated with the estimate: 30%); middle value at least 1.6-fold (0.22 log units) from the limit.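

Compound 4 returns a limit of the assay, not a number, so the methyl on the phenyl can be read only as a floor that shows no firm change: an at least 1.3-fold higher number from compound 3 to compound 4 (0.12 log units; that floor lies within the scatter). The new result does show that 2-methylphenyl in place of hex-1-yn-1-yl is a large change, with an at least 100-fold higher number from compound 1 to compound 4 (2.00 log units; beyond the scatter). The step between compound 2 and compound 4 cannot be read, and the reading of this position ends at a shared ceiling: the limit of > 100000 nM in this assay, at which 2 of the 4 values shown sit.

On these data alone, whether an amine or a carboxylic acid on the phenyl would lower the number stays open. So does whether a chain longer than hex-1-yn-1-yl would do so.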